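Chloro in place of acetoxy on the side chain

A few compounds are considered here, and "the series" means these few. Any claim that something is new, unique, unknown or untested is made for them only; others in the source may bear on it.

compound 1 `COc1nc(C)c(CCO)c(OC)n1`: > 100000 nM, a limit of the assay
compound 2 `COc1nc(C)c(CCOC(C)=O)c(OC)n1`: 44000 nM

In a functional assay on SW-620 cells (Homo sapiens) for antiproliferative activity, read by MTT assay, with a stated time of 24 h (a higher number here means a weaker inhibitor, a lower number a stronger inhibitor), compound 1 gives only a limit, > 100000 nM. In this assay, among the compounds with values here, compound 2 gives 44000 nM, the only number among the two values shown. The step of an at least 2.2-fold lower number from compound 1 to compound 2 (0.35 log units; beyond the scatter) sets compound 2 apart from compound 1, whose value sits at the limit of > 100000 nM in this assay, at which 1 of the 2 values shown sits.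

Compound 3 `COc1nc(C)c(CCCl)c(OC)n1` is not yet measured. It differs from compound 2 by chloro in place of acetoxy on a saturated chain carbon, two bonds along the chain from an aromatic carbon. Within the data shown here, no measured step covers this exchange: the one step known changes the group on the oxygen, while here the oxygen leaves altogether. Among the measured compounds shown here, with no bearing step available, a number near that of compound 2 is the plainest expectation, with wide uncertainty in both directions.

For compound 3 the estimate in this assay is 30000 nM, between 8000 nM and 100000 nM. This corresponds to an expected step of a 1.5-fold lower number from compound 2 to compound 3 (0.17 log units; within the scatter), not beyond the scatter.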

Compound 3, half-maximal inhibitory concentration: > 100000 nM
Compound 3 gave a limit, no number (the forecaster's own chance of this, stated with the estimate: 25%); middle value at least 3.3-fold (0.52 log units) away from the limit.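

Among the groups shown on this saturated chain carbon, only acetoxy gives a number in this assay, and that number is not kept with chloro in its place: an at least 2.2-fold higher number from compound 2 to compound 3 (0.35 log units; beyond the scatter). The step joining compound 1 and compound 3 cannot be read, as both values are limits of the assay. Hydroxy and chloro at this position are therefore not told apart, and the acetoxy compound alone stands clear of them: the limit of > 100000 nM in this assay, at which 2 of the 3 values shown sit.

Open, from the compounds shown here alone, is whether an amine, a carboxylic acid, a benzoate ester or a longer chain at this position would give a number in this assay, and how such a number would stand against compound 2. With a single number in the series, no trend across groups at this position can yet be stated.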